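A few compounds are considered here, and "the series" means these few. Any claim that something is new, unique, unknown or untested is made for them only; others in the source may bear on it.

Compound 1, `Nc1nc2c(ncn2/C=C2/C[C@H]2[C@@H](O)CO)c(=O)[nH]1`, was examined in an ADME assay on HFF cells (Homo sapiens) for cytotoxicity, read by neutral red uptake (on this read-out lower numbers stand for higher toxicity in this test and higher numbers for lower toxicity in this test), and compound 1 gave 299000 nM. Compound 2, `Nc1ncnc2c1ncn2/C=C1/C[C@H]1[C@H](O)CO`, is the second member of this small set; in this assay compound 2 gave 206000 nM. Compound 2 has no neighbour beyond compound 1, and its number sits within the usual scatter of the number of compound 1, so the two compounds cannot be told apart on this read-out.

The next compound, compound 3, `Nc1ncnc2c1ncn2/C=C1/C[C@@H]1[C@H](O)CO`, is not yet measured. Its relation to compound 2 is the two compounds have the same atoms and bonds and differ only in configuration as drawn: 1 of 3 stereo elements differ; a stereocentre at a saturated ring carbon is drawn R in compound 2 and S in compound 3. Among the measured compounds shown here, no step between measured compounds exists here that would show how such a change of configuration acts in this assay. Because compound 2 gave 206000 nM, compound 3 is expected to stay close to it, with the step of a 1.0-fold higher number from compound 2 to compound 3 (0.01 log units; within the scatter) expected to remain within the scatter. Compound 3 is estimated to give 210000 nM, with a range from 100000 nM to 420000 nM.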

Compound 3, half-maximal cytotoxic concentration: > 300000 nM
Compound 3 gave a limit, no number; the forecaster's own chance of this, stated with the estimate: 20%; middle value at least 1.4-fold (0.15 log units) away from the limit.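

Compound 3 gives > 300000 nM in this assay, which is a limit of the assay and not a number. Among the compounds shown here, the first step of this set that can be read is an at least 1.4-fold higher number from compound 2 to compound 3 (0.16 log units; that floor lies within the scatter), and it concerns a single change, the stereocentre at a saturated ring carbon going from R to S, so the floor of the step is all that this pair gives on configuration. Whatever separates the two compounds in this test can have only one source: the fact that compounds 2 and 3 differ only in the configuration as drawn

On these data alone, whether this change of configuration moves the read-out at all, and by how much, remains open. Also open, as far as these compounds go, is how a carboxylic acid or a fluorine atom on the shared core would read in this assay.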